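Adding a Methyl to the Sulfonyl Ring

This account rests on a few compounds, and the source may have more. Where it says the series, first, only, none or still open, it means among the compounds named here.

Compound 1 `Cc1ccc(S(=O)(=O)NC(=O)/C=C/c2ccccc2)cc1` gives 13.8 ug/mL in a functional assay on B16-F10 cells (Mus musculus) for antiproliferative activity, read by ELISA and MTT assay, with a stated time of 48 h; on this read-out lower numbers stand for stronger inhibition and higher numbers for weaker inhibition.
Compound 2 `Cc1ccc(S(=O)(=O)NC(=O)/C=C/c2ccc(Cl)cc2)cc1` gives 4.6 ug/mL.
Compound 3 `CN(C)c1ccc(/C=C/C(=O)NS(=O)(=O)c2ccccc2)cc1` gives 2.3 ug/mL.

Compound 3 shows the lowest of the three numbers, though its gap to compound 2 lies within the usual scatter of this kind of measurement; only compound 1 sits clearly beyond it. Compound 4 `Cc1ccc(S(=O)(=O)NC(=O)/C=C/c2ccc(N(C)C)cc2)cc1` differs from compound 3 by methyl in place of hydrogen on an aromatic carbon. For the measured compounds named here, the single measured step, a 3.0-fold lower number from compound 1 to compound 2 (0.48 log units; beyond the scatter), concerns a chloro on the other aromatic ring, so it does not speak directly to a methyl at this position. Going by the values given here, with no comparable step, no change beyond the scatter is expected in this assay. Compound 4 is therefore estimated at 2.3 ug/mL, with a range from 1 ug/mL to 5 ug/mL. This corresponds to an expected step of no change at the digits printed from compound 3 to compound 4 (within the scatter).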

Compound 4, half-maximal inhibitory concentration: 4.3 ug/mL
Compound 4: the middle estimate sits 1.9-fold (0.27 log units) below what was measured; the measured number falls inside the stated range.
By their numbers in this assay, from the lowest: compounds 3, 4 and 2 (each within the scatter of the next); then compound 1.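

In this assay the change from phenyl to 4-methylphenyl gives a 1.9-fold higher number from compound 3 to compound 4 (0.27 log units; within the scatter) and so shows that a methyl at this place shifts the number by no more than the scatter. On the other aromatic ring, dimethylamino in place of hydrogen gives a 3.2-fold lower number from compound 1 to compound 4 (0.51 log units; beyond the scatter) and stands clear of the scatter, while dimethylamino in place of chloro gives a 1.1-fold lower number from compound 2 to compound 4 (0.03 log units; within the scatter) and does not separate those two groups. No evidence here offers a reason for these steps. Going by these compounds, whether an ethyl, a methoxy or a carboxylic acid at the methyl's place would match the methyl remains open.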